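From 2,5-dimethylphenyl to phenyl in compound 1

This account rests on a few compounds, and the source may have more. Where it says the series, first, only, none or still open, it means among the compounds named here.

For the measured compounds named here, three related compounds have numbers so far in a functional assay on MDA-MB-231 cells (Homo sapiens) for inhibition, with a stated time of 72 h; on this read-out higher numbers stand for weaker inhibition and lower numbers for stronger inhibition. Compound 1 `Cc1ccc(C)c(NC(=O)Nc2nc(Sc3c[nH]c4ccccc34)cc(N3CCCCC3)n2)c1` gives 5940 nM. Compound 3 `Cc1cc(Cl)ccc1NC(=O)Nc1nc(Sc2c[nH]c3ccccc23)cc(N2CCCC2)n1` gives 9440 nM, which lies within the scatter of the value for compound 1. Compound 2 `Cc1ccc(C)c(NC(=O)Nc2nc(Sc3c[nH]c4ccccc34)cc(N3CCN(Cc4ccccc4)CC3)n2)c1` gives 19000 nM, a number beyond the scatter from compound 1 and so a weaker inhibition. Compound 1 therefore sits in the better part of this small set, level with compound 3.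

Compound 4 `O=C(Nc1ccccc1)Nc1nc(Sc2c[nH]c3ccccc23)cc(N2CCCCC2)n1` keeps the shared core and the ring-bearing groups of compound 1 and changes one thing: phenyl in place of 2,5-dimethylphenyl on an amide-type nitrogen. Going by the values given here, no two measured compounds differ only at this place, so the data give no direct guide to this change. The expected step, a 1.3-fold higher number from compound 1 to compound 4 (0.13 log units; within the scatter), is small, most likely within the scatter, with a slight lean toward weaker inhibition. For compound 4 the estimated value is 8000 nM, with an expected range of 3000 nM to 20000 nM.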

Compound 4, half-maximal inhibitory concentration: 8130 nM
For compound 4 the middle estimate is 1.0-fold (0.01 log units) below the measured one, and the stated range covers the measured number.
By their numbers in this assay, from the lowest: compounds 1, 4, 3 and 2 (each within the scatter of the next, the first and the last beyond it).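

Putting phenyl in place of 2,5-dimethylphenyl on an amide-type nitrogen gives a 1.4-fold higher number from compound 1 to compound 4 (0.14 log units; within the scatter) in this assay, so the two compounds cannot be told apart on this read-out. This is the first pair shown that differs in only one place, and it shows that the plain phenyl holds the level of inhibition seen with 2,5-dimethylphenyl, at least with the rest of compound 1 unchanged. Nothing measured here explains this result.

As far as these compounds go, whether a different group at this position, such as a phenyl carrying a carboxylic acid or an amine, would move the number beyond the scatter remains open. It is also unknown whether this tolerance would hold with the other groups seen in this set, or whether a phenyl carrying a single methyl would behave the same way.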